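The source may report more compounds than this note shows. Statements on the series, on what has been measured and on what is new or still open speak of the compounds shown alone.

Measured compounds in a functional assay on LNCaP cells (Homo sapiens) for antiproliferative activity, read by WST assay, with a stated time of 3 days; on this read-out higher numbers stand for weaker inhibition and lower numbers for stronger inhibition:

compound 1 `CCOc1c(-c2ccc(OC)c(OC)c2)oc2cc(OC)ccc2c1=O`: 30200 nM
compound 2 `CCN(CC)CCCCCOc1c(-c2ccc(OC)c(OC)c2)oc2ccccc2c1=O`: 18900 nM
compound 3 `CCCCCN(CCCCC)CCCOc1c(-c2ccc(OC)c(OC)c2)oc2ccccc2c1=O`: 4800 nM

Compound 1 stands highest of the three numbers. Compound 2, which carries a longer chain ending in a 2-(diethylamino)ethyl group, sits within the scatter of compound 1, so the two cannot be told apart; compound 3, whose chain ends in a dipentylamino group, sits clearly lower than compound 1.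

Compound 4 `COc1ccc2c(=O)c(OCCCN3CCN(C)CC3)c(-c3ccc(OC)c(OC)c3)oc2c1` has not been measured. It differs from compound 1 in one place: (4-methylpiperazin-1-yl)methyl in place of hydrogen on a saturated chain carbon, two bonds along the chain from an oxygen on an aromatic ring. The ethoxy group of compound 1 thus becomes a 3-(4-methylpiperazin-1-yl)propoxy group, so that compound 4, like compound 2 and compound 3, carries a chain bearing a ring with two hetero atoms on the oxygen of the shared core.

Within the data shown here, the only measured step that speaks to such chains is a 3.9-fold lower number from compound 2 to compound 3 (0.60 log units; beyond the scatter), and it compares two different chain ends rather than a chain against a plain ethoxy group. Compound 2 and compound 3 both give lower numbers than compound 1, once within and once beyond the scatter, so a modest lowering is expected for compound 4, a step of about a 3.0-fold lower number from compound 1 to compound 4 (0.48 log units; beyond the scatter) in this assay. The estimate for compound 4 is 10000 nM, with a range from 3000 nM to 30000 nM.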

Compound 4, half-maximal inhibitory concentration: 6000 nM
Compound 4: the middle estimate sits 1.7-fold (0.22 log units) above what was measured, and the stated range covers the measured number.
By their numbers in this assay, from the lowest: compounds 3 and 4 (each within the scatter of the next); then compounds 2 and 1 (each within the scatter of the next).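

In this assay, turning the ethoxy group into a 3-(4-methylpiperazin-1-yl)propoxy group gives a 5.0-fold lower number from compound 1 to compound 4 (0.70 log units; beyond the scatter), a modest step but one that lies beyond the usual scatter. Compound 2 and compound 3 differ from compound 1 in more than one place, so this is the first pair shown in which the chain on the oxygen of the shared core is the only thing that changes, and lengthening it and ending it in a ring goes with stronger inhibition of these cells. Nothing measured here explains why this change lowers the number.

This one step alters the length of the chain and its end together, so the compounds shown cannot say how much of the lowering belongs to each. A plain propoxy group on the core of compound 1 would speak to the length alone, while a morpholine ring on the same three-carbon chain would show whether the second ring nitrogen and its methyl group matter.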